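A few compounds are considered here, and "the series" means these few. Any claim that something is new, unique, unknown or untested is made for them only; others in the source may bear on it.

In a functional assay on Bel-7402 cells (Homo sapiens) for inhibition, read by MTT assay, with a stated time of 24 h, tested at 100 ug/mL (a lower number here means less inhibition of growth, a higher number more inhibition of growth at the concentration tested), compound 1 `O=C(O)CCCCC(CCSC(=O)c1ccccc1)SC(=O)c1ccccc1` gives 81% and compound 2 `O=C(CCCCC1CCSS1)Nc1ccc(OC(F)(F)F)cc1` gives 78.4% so these two lie within the scatter of each other. Compound 3 `O=C(CCCCC1CCSS1)Nc1ccc(Cl)cn1` stands at 48.5% and lies beyond the scatter below compound 1. Compound 1 therefore shares the upper end of these numbers with compound 2. Going by the values given here, compound 4 `O=C(CCCCC(CCSC(=O)c1ccccc1)SC(=O)c1ccccc1)Nc1cccc(Cl)c1` differs from compound 1 by (3-chlorophenyl)amino in place of hydroxy on a carbonyl carbon and no measured pair shows this change alone. Compound 2 at 78.4% and compound 3 at 48.5% both carry an aromatic ring on an amide nitrogen, so a moderate fall in this assay is expected. The estimated step is a number 16 percentage points lower from compound 1 to compound 4 (beyond the scatter) and would lie just beyond the scatter. Compound 4 is expected at 65% with an estimated range from 45% to 85% in this read-out.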

Compound 4, percent growth inhibition at one concentration: "not active" (no number reported)
Compound 4 has no reported number here; no gap can be computed for the estimate.
By their numbers in this assay, from the lowest: compound 3; then compounds 2 and 1 (each within the scatter of the next).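

In this assay, going by these compounds alone, compound 4 is reported as "not active" without a number, so no step from compound 1 can be read. How far (3-chlorophenyl)amino in place of hydroxy shifts growth inhibition stays open, and no supporting data explain the result.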